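Adding a Second Methoxy Group to Compound 2

The compounds below may be only part of what the source reports. "The series", "measured", "known", "first", "only" and "open" are said of these compounds alone.

Compound 1 `O=C(N/N=C/c1cccc(Cl)c1)c1cccnc1Nc1cccc(C(F)(F)F)c1`: 40.4%
Compound 2 `COc1ccc(/C=N/NC(=O)c2cccnc2Nc2cccc(C(F)(F)F)c2)cc1`: 14%

In a functional assay on the whole organism (strain Wistar) for inhibition, with Rattus norvegicus as the target, read by paw edema, with a stated time of 4 h, at a dose of 10 mg/kg by the intraperitoneal route (a higher number here means more inhibition at the dose given (going by the name of the read-out), a lower number less inhibition), compound 1 gives 40.4% and compound 2 gives 14%, the lowest of the two numbers. Compound 3 `COc1ccc(/C=N/NC(=O)c2cccnc2Nc2cccc(C(F)(F)F)c2)cc1OC` differs from compound 2 by methoxy in place of hydrogen on an aromatic carbon. For the measured compounds named here, the only measured step, a number 26.4 percentage points lower from compound 1 to compound 2 (beyond the scatter), exchanges the whole group on the carbon with a double bond to nitrogen and does not test the addition of a methoxy group to that ring. Going by the values given here, with no direct precedent, compound 3 is expected to show no step beyond the scatter, a number 2 percentage points higher from compound 2 to compound 3 (within the scatter). Compound 3 is estimated at 16%, within 4% to 32%.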

Compound 3, a percentage reported as inhibition, in the whole organism at one dose (the size of the read-out at that dose, not a potency): 52.9%
Compound 3: the middle estimate sits 36.9 percentage points below what was measured, outside the stated range (above it).
By their numbers in this assay, from the lowest: compound 2; then compound 1; then compound 3.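

In this assay the step of a number 38.9 percentage points higher from compound 2 to compound 3 (beyond the scatter) tests one added methoxy group alone, on an aromatic carbon ortho to the existing methoxy group, and this small addition changes the result greatly. The step of a number 12.5 percentage points higher from compound 1 to compound 3 (beyond the scatter) shows that 3,4-dimethoxyphenyl surpasses 3-chlorophenyl, so the low number of compound 2 does not extend to every methoxy-bearing ring in this set. No measurement available here explains the size of this gain. On these data alone, whether a hydroxyl group, an amine or a longer ethoxy chain at this place would give a similar number remains open.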